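From 2-Chlorophenyl to 3-Bromophenyl on an Amide Nitrogen

The source may report more compounds than this note shows. Statements on the series, on what has been measured and on what is new or still open speak of the compounds shown alone.

Compound 1 `Cc1ccc(NC(=O)c2ccc3cccc(O)c3n2)cc1` and compound 2 `O=C(Nc1ccccc1Cl)c1ccc2cccc(O)c2n1` share one core and differ only in the group on the amide-type nitrogen. In an ADME assay on THP-1 cells (Homo sapiens) for cytotoxicity, read by WST assay, with a stated time of 24 h (a lower number here means a stronger inhibitor, a higher number a weaker inhibitor), compound 1 gives > 30000 nM, which is a limit of the assay. In this assay compound 2 gives > 30000 nM, also a limit. The step that the two limits leave unreadable from compound 1 to compound 2 thus has no readable size; both values sit at the limit of > 30000 nM in this assay, at which 2 of the 2 values shown sit. Compound 3 `O=C(Nc1cccc(Br)c1)c1ccc2cccc(O)c2n1` carries 3-bromophenyl in place of 2-chlorophenyl on an amide-type nitrogen. With no readable measured step to lean on, no change beyond the scatter is expected in this assay. Compound 3 is estimated at 40000 nM, within 15000 nM to 100000 nM, an expected step that the limit leaves unreadable from compound 2 to compound 3.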

Compound 3, half-maximal inhibitory concentration: > 30000 nM
Compound 3 was reported as a limit; the forecaster's own chance of this, stated with the estimate: 80%; the middle value does not contradict the limit.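

No step can be read between compound 1, compound 2 and compound 3, because all three stand at one limit: (the limit of > 30000 nM in this assay, at which 3 of the 3 values shown sit). The compounds shown leave open how far apart their true values lie, and whether any group on the amide-type nitrogen gives a readable value.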